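A Chlorophenyl Exchange on the Sulfonyl Sulfur

The source may report more compounds than this note shows. Statements on the series, on what has been measured and on what is new or still open speak of the compounds shown alone.

In an ADME assay on HEK-293T cells (Homo sapiens) for inhibition, read by CCK-8 assay, with a stated time of 48 h, tested at 20 uM (a lower number here means less inhibition of growth, a higher number more inhibition of growth at the concentration tested), compound 1 (`Cc1ccc(Cc2nnc(NC(=O)/C(C#N)=C/c3ccccc3OS(=O)(=O)c3ccc([N+](=O)[O-])cc3)s2)cc1`) gives 9% and compound 2 (`Cc1ccc(Cc2nnc(NC(=O)/C(C#N)=C/c3ccccc3OS(=O)(=O)c3ccccc3[N+](=O)[O-])s2)cc1`) gives 6% at the concentration tested. The two values lie within the scatter of each other, so compound 2 stands level with compound 1, and both show little inhibition of growth.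

Compound 3 (`Cc1ccc(Cc2nnc(NC(=O)/C(C#N)=C/c3ccccc3OS(=O)(=O)c3ccc(Cl)cc3)s2)cc1`) has not yet been measured. It carries 4-chlorophenyl in place of 2-nitrophenyl on a sulfonyl sulfur. Among the compounds with values here, one measured step bears on this change: 2-nitrophenyl in place of 4-nitrophenyl on a sulfonyl sulfur gave a number 3 percentage points lower from compound 1 to compound 2 (within the scatter) and so stayed within the scatter. Within the data shown here, both compounds of that step keep a nitrophenyl group, and no measurement yet covers 4-chlorophenyl, so the evidence is thin.

Starting from compound 2 at 6% again, no step beyond the scatter is expected in this assay and no direction is favoured. The step expected is a number 3 percentage points higher from compound 2 to compound 3 (within the scatter) by this estimate. In this assay compound 3 is therefore estimated at 9% (expected range 0% to 22%).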

Compound 3, percent growth inhibition at one concentration: 8%
For compound 3 the middle estimate is 1 percentage points above the measured one; the measured number falls inside the stated range.
By their numbers in this assay, from the lowest: compounds 2, 3 and 1 (each within the scatter of the next).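

Within the data shown here, compound 3 is the first of the set whose sulfonyl sulfur carries no nitrophenyl group, so it tests what the earlier pair could not: whether the nitro group matters to the reading at this position. In this assay, 4-chlorophenyl in place of 2-nitrophenyl gives a number 2 percentage points higher from compound 2 to compound 3 (within the scatter), and chloro in place of nitro on an aromatic carbon gives a number 1 percentage points lower from compound 1 to compound 3 (within the scatter), so all three compounds stand level and little inhibition of growth is seen with either a nitro or a chloro substituent on this aromatic ring. The data therefore extend the flat picture from a shift of the nitro group to an exchange of the substituent itself, but no measurement at hand offers an explanation for this level reading.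

The compounds shown leave open whether a different substituent on this aromatic ring, such as an amine, a carboxylic acid or a methoxy group, would stay level with these three or move beyond the scatter. They also leave open what happens when the aromatic ring on the sulfonyl sulfur gives way altogether to a longer alkyl chain.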